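Swapping chloro for methoxy on a pyrazole hydrazone

The source may report more compounds than this note shows. Statements on the series, on what has been measured and on what is new or still open speak of the compounds shown alone.

Measured compounds so far:
- compound 1, `COc1ccc(-c2cc(C(=O)N/N=C/c3ccccc3O)n(Cc3ccc(Cl)nc3)n2)cc1`: 8210 nM
- compound 2, `O=C(N/N=C/c1ccccc1O)c1cc(-c2ccccc2)nn1Cc1ccccc1`: 10800 nM
- compound 3, `O=C(N/N=C/c1ccccc1O)c1cc(-c2ccc(Cl)cc2)nn1Cc1ccccc1`: 4870 nM

These three compounds were tested in a functional assay on A549 cells (Homo sapiens) for cytotoxicity, read by MTT assay, with a stated time of 96 h; on this read-out lower numbers stand for stronger inhibition and higher numbers for weaker inhibition. Compound 3 gives the lowest of the three numbers in this assay. Within the data shown here, its nearest neighbour is compound 1, whose number lies within the usual scatter of compound 3, so the two cannot be told apart; compound 2 sits beyond the scatter, and the step of a 2.2-fold lower number from compound 2 to compound 3 (0.35 log units; beyond the scatter) is the only single-point change measured.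

The next compound, compound 4 (`COc1ccc(-c2cc(C(=O)N/N=C/c3ccccc3O)n(Cc3ccccc3)n2)cc1`), differs from compound 3 in one place: methoxy in place of chloro on an aromatic carbon. Among the measured compounds shown here, no measured pair isolates this exact change. The closest hint is compound 1, which also carries methoxy on that ring but a different group on the ring nitrogen, and whose value is within the scatter of compound 3. The step from compound 2 to compound 3 shows that removing chloro alone cost a modest amount, which methoxy may or may not recover.

On that basis compound 4 is expected to give 7000 nM in this assay, with a range from 3500 nM to 14000 nM. This amounts to an expected step of a 1.4-fold higher number from compound 3 to compound 4 (0.16 log units; within the scatter), a change that is likely to stay within the scatter.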

Compound 4, half-maximal inhibitory concentration: 7690 nM
Estimate against measurement, compound 4: 1.1-fold (0.04 log units) below; low and high end bracket the measured number.
By their numbers in this assay, from the lowest: compounds 3, 4, 1 and 2 (each within the scatter of the next, the first and the last beyond it).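

In this assay there is a 1.6-fold higher number from compound 3 to compound 4 (0.20 log units; within the scatter) when methoxy takes the place of chloro on this aromatic carbon, and there is a 1.4-fold lower number from compound 2 to compound 4 (0.15 log units; within the scatter) when methoxy takes the place of hydrogen there. Methoxy therefore cannot be told apart from either chloro or hydrogen at this position, even though chloro and hydrogen are separated by a 2.2-fold lower number from compound 2 to compound 3 (0.35 log units; beyond the scatter) in the same assay; among these three groups, only that pair gives a step beyond the usual scatter. With methoxy on the aromatic ring, the other change also gives no readable difference: phenyl in place of 6-chloropyridin-3-yl on the saturated chain carbon bound to an aromatic nitrogen gives a 1.1-fold lower number from compound 1 to compound 4 (0.03 log units; within the scatter) and so stays within the scatter.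

The compounds shown leave open whether a different kind of group on this same aromatic carbon, such as an amine or a carboxylic acid, would move the number further than chloro does. Nothing given here bears on why these numbers fall as they do.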